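The compounds below may be only part of what the source reports. "The series", "measured", "known", "first", "only" and "open" are said of these compounds alone.

Working notes on the series. In a functional assay on HepG2 cells (Homo sapiens) for cytotoxicity, read by MTT assay (a higher number here means a weaker inhibitor, a lower number a stronger inhibitor), compound 2 (`COc1ccc(/C=C/C(=O)c2ccc(OC)c3c2OC(C)(C)C=C3)cc1OCCO`) stands at > 10000 nM and this is a limit of the assay, not a number. Compound 1 (`COc1ccc(/C=C/C(=O)c2ccc(OC)c3c2OC(C)(C)C=C3)cc1O`) with hydrogen on the oxygen in question gives 450 nM and compound 3 (`CCCCC(=O)Oc1cc(/C=C/C(=O)c2ccc(OC)c3c2OC(C)(C)C=C3)ccc1OC`) with butylcarbonyl there gives 100 nM in the same read-out.

The step followed here runs to compound 4 (`COc1cccc(C(=O)Oc2cc(/C=C/C(=O)c3ccc(OC)c4c3OC(C)(C)C=C4)ccc2OC)c1`) with (3-methoxyphenyl)carbonyl in place of 2-hydroxyethyl on an oxygen on an aromatic ring. The nearest measured precedent is the change to butylcarbonyl on the same oxygen (an at least 100-fold lower number from compound 2 to compound 3 (2.00 log units; beyond the scatter)) which is large and beyond the scatter. The other two steps frame it: 2-hydroxyethyl in place of hydrogen gave a large step up (an at least 22-fold higher number from compound 1 to compound 2 (1.34 log units; beyond the scatter)) and butylcarbonyl in place of hydrogen gave a modest step down (a 4.5-fold lower number from compound 1 to compound 3 (0.65 log units; beyond the scatter)).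

Among the measured compounds shown here, compound 4 shares the carbonyl on that oxygen with compound 3, but no measured compound carries an aromatic ring in this group, so the read-across is loose. A large step down is still expected, and its estimated size is (an at least 50-fold lower number from compound 2 to compound 4 (1.69 log units; beyond the scatter)) in this assay here. For compound 4 the estimated value is 200 nM with an expected range from 40 nM to 1000 nM in this read-out.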

Compound 4, half-maximal inhibitory concentration: 870 nM
Compound 4: the middle estimate sits 4.4-fold (0.64 log units) below what was measured, within the range that was stated.
By their numbers in this assay, from the lowest: compound 3; then compounds 1 and 4 (each within the scatter of the next). At a limit, above all of these: compound 2.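

In this assay, (3-methoxyphenyl)carbonyl on this oxygen also stands well clear of 2-hydroxyethyl, an at least 11-fold lower number from compound 2 to compound 4 (1.06 log units; beyond the scatter), so the butyl ester of compound 3 is not alone in this. Compound 2 stands at a limit of the assay, not a number: the limit of > 10000 nM in this assay, at which 1 of the 4 values shown sits. The group on the carbonyl carbon still counts, with an 8.7-fold higher number from compound 3 to compound 4 (0.94 log units; beyond the scatter), and against the free hydroxyl of compound 1 the aromatic ester shows no readable difference, a 1.9-fold higher number from compound 1 to compound 4 (0.29 log units; within the scatter), whereas the butyl ester gave a 4.5-fold lower number from compound 1 to compound 3 (0.65 log units; beyond the scatter), so a carbonyl on this oxygen does not by itself bring the number down.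

The compounds shown leave open whether the gap between butyl and 3-methoxyphenyl belongs to the aromatic ring or to its methoxy group, a question that a plain phenyl and a chain longer than butyl on the same carbonyl would bear on. From the compounds shown here alone, it also remains open whether the loss seen with 2-hydroxyethyl belongs to the ether link or to the terminal hydroxyl, which a simple ethyl ether or an aminoethyl group on this oxygen would help to separate.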